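Chloro for fluoro on compound 2

The compounds below may be only part of what the source reports. "The series", "measured", "known", "first", "only" and "open" are said of these compounds alone.

In a functional assay on MCF7 cells (Homo sapiens) for antiproliferative activity, read by MTT assay, with a stated time of 48 h (a lower number here means a stronger inhibitor, a higher number a weaker inhibitor), compound 1 `Clc1ccc2[nH]c(-c3cn(-c4ccccc4)nc3-c3ccccc3)nc2c1` gives 1960 nM, and compound 2 `Fc1ccc(-c2nn(-c3ccccc3)cc2-c2nc3cc(F)ccc3[nH]2)cc1` gives 950 nM. Compound 2 holds the lower of the two numbers, and the gap between them lies just beyond the usual scatter. Going by the values given here, the series offers no measured step between compounds that differ in one place, so the size of the next step has to be judged from these two values and the structural change alone.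

Compound 3 `Fc1ccc(-c2nn(-c3ccccc3)cc2-c2nc3cc(Cl)ccc3[nH]2)cc1` has chloro in place of fluoro on an aromatic carbon of compound 2 (chloro in place of fluoro on an aromatic carbon). The carbon belongs to a six-membered aromatic ring of carbon only, part of a fused or bridged system of two rings. In this assay no step beyond the scatter is expected, with at most a slight drift towards a higher number. Among the compounds with values here, the range is kept wide, reaching up past compound 1 at 1960 nM, since no measured step supports it. The expected 1.3-fold higher number from compound 2 to compound 3 (0.10 log units; within the scatter) is small. For compound 3 the estimated value is 1200 nM, with an expected range of 500 nM to 2800 nM.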

Compound 3, half-maximal inhibitory concentration: 2230 nM
Compound 3: the middle estimate sits 1.9-fold (0.27 log units) below what was measured; the range from low to high includes it.
By their numbers in this assay, from the lowest: compound 2; then compounds 1 and 3 (each within the scatter of the next).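

In this assay, chloro in place of fluoro on this aromatic carbon of the ring fused into the two-ring system gives a 2.3-fold higher number from compound 2 to compound 3 (0.37 log units; beyond the scatter), a modest step but one beyond the scatter, so the two halogens are not interchangeable at this position in the setting of compound 2. With chloro held at this position, fluoro in place of hydrogen on an aromatic carbon gives a 1.1-fold higher number from compound 1 to compound 3 (0.06 log units; within the scatter), which stays within the scatter and shows no measurable effect of that second change. No measured evidence bears on what lies behind either step.

The compounds shown hold only fluoro and chloro at this position, so how a hydrogen, a methoxy group or an amine on the same aromatic carbon would read remains open. Also open, on these data alone, is whether the chloro-for-fluoro step would keep its size on the core of compound 1, with hydrogen in place of the other fluoro.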